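The source may hold more compounds than are shown below. What is called first, only, known or untested is meant among the compounds shown, and "the series" means these compounds.

Measured so far in a functional assay on Jurkat cells (Homo sapiens) for antiproliferative activity, read by MTT assay, with a stated time of 72 h; a lower number here means a stronger inhibitor, a higher number a weaker inhibitor:
- compound 1 `CNc1nc(-c2cc(OC)c(OC)c(OC)c2)c(-c2ccc3ccccc3c2)s1`: 51.1 nM
- compound 2 `COc1cc(-c2nc(N(C)C)sc2-c2ccc3ccccc3c2)cc(OC)c1OC`: 836 nM

Of these two, compound 2 has the higher number, at 836 nM, and is the weaker inhibitor. For the measured compounds named here, the only measured step, a 16-fold higher number from compound 1 to compound 2 (1.21 log units; beyond the scatter), is large and lies beyond the scatter. It comes from methyl in place of hydrogen on a nitrogen on an aromatic ring.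

Compound 3 `COc1ccc(-c2sc(N(C)C)nc2-c2cc(OC)c(OC)c(OC)c2)cc1` retains the dimethylamino group of compound 2 and differs elsewhere: 4-methoxyphenyl in place of naphthalen-2-yl on an aromatic carbon. This is 4-methoxyphenyl in place of naphthalen-2-yl on an aromatic carbon, next to the ring sulfur. The measured step lies at another place, so no measurement bears directly on this change, and the direction in this assay remains uncertain. A modest move towards a lower number is tentatively expected, with a wide margin on either side. The expected step is a 2.1-fold lower number from compound 2 to compound 3 (0.32 log units; beyond the scatter). For compound 3 the estimated value is 400 nM, with an expected range from 80 nM to 2500 nM.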

Compound 3, half-maximal inhibitory concentration: 7600 nM
Compound 3: middle estimate off by 19-fold (1.28 log units), on the low side, outside the stated range (above it).
By their numbers in this assay, from the lowest: compound 1; then compound 2; then compound 3.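

The aromatic carbon next to the ring sulfur now has its first measured change: in this assay, 4-methoxyphenyl in place of naphthalen-2-yl gives a 9.1-fold higher number from compound 2 to compound 3 (0.96 log units; beyond the scatter), so with the dimethylamino group held constant, the group at this position clearly matters to the read-out. The change removes one of the two six-membered aromatic rings of carbon only and brings in one hydrogen-bond acceptor, and as both occur in the same step, this single pair cannot separate them. No measured evidence is available to explain the size of this step.

Open is whether the same exchange would give a comparable step on the core of compound 1, which keeps a hydrogen on the nitrogen, since no pair shown tests it there. Also open, on these data alone, is whether the loss of the second ring or the arrival of the methoxy oxygen accounts for the step, a question that a plain phenyl or a 4-chlorophenyl at this position, compared with compound 2 and compound 3, would help to settle.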